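Methoxy in place of hydrogen on the pendant phenyl

The source may report more compounds than this note shows. Statements on the series, on what has been measured and on what is new or still open speak of the compounds shown alone.

Compound 1, `Cc1cc(-c2ccccc2)c2ncc(CSCCc3ccccc3)n2c1`, has been measured in an ADME assay on HEL cells (Homo sapiens) for cytotoxicity, with a stated time of 3 days (a lower number here means that less compound is tolerated, a higher number that more compound is tolerated), and gives 33 ug/mL. That is the lowest of the two numbers in hand, yet its nearest neighbour, compound 2, `COc1cccc(-c2cc(C)c3ncc(CSCCc4ccccc4)n3c2)c1`, gives 36 ug/mL, and the gap between the two lies within the scatter, so this assay does not tell them apart. Compound 3, `COc1ccc(-c2cc(C)cn3c(CSCCc4ccccc4)cnc23)cc1`, is still to be measured. Relative to compound 1 the change is methoxy in place of hydrogen on an aromatic carbon. Among the measured compounds shown here, no measured pair follows this exact step, so its size cannot be read from an analogue; what the two numbers show is that compound 2 gives 36 ug/mL while compound 1 gives 33 ug/mL. On that basis the step of a 1.1-fold higher number from compound 1 to compound 3 (0.03 log units; within the scatter) is expected to stay within the scatter. Compound 3 is estimated at 35 ug/mL, with a range from 18 ug/mL to 70 ug/mL.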

Compound 3, half-maximal cytotoxic concentration: 19.6 ug/mL
Estimate against measurement, compound 3: 1.8-fold (0.25 log units) above; the measured number falls inside the stated range.
By their numbers in this assay, from the lowest: compounds 3, 1 and 2 (each within the scatter of the next).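

In this assay, among the compounds shown here, the first direct reading at this position is a 1.7-fold lower number from compound 1 to compound 3 (0.23 log units; within the scatter) for phenyl to 4-methoxyphenyl, so the step lies within the scatter. With methoxy in place of hydrogen on an aromatic carbon, para to a large group, this assay does not separate compound 3 from compound 1, and this single pair gives no sign of a change in tolerated concentration from this replacement. No measured evidence on the origin of the lower number accompanies this step.

From the compounds shown here alone, it remains open whether an amine or a carboxylic acid on the same aromatic carbon would give a step beyond the scatter. A single pair also leaves open whether the methoxy step would read the same on a different chain in place of the sulfur-bearing side chain of compound 1.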